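The source may report more compounds than this note shows. Statements on the series, on what has been measured and on what is new or still open speak of the compounds shown alone.

Working notes on the series. Compound 2 `CC(C(=O)NCc1ccc(C(F)(F)F)nc1-c1ccc(C(C)(C)C)cc1)c1ccc(NS(C)(=O)=O)c(F)c1` has been measured in an assay on CHO cells for antagonist activity at transient receptor potential cation channel subfamily V member 1 (Homo sapiens), read by FLIPR; on this read-out lower numbers stand for stronger inhibition and higher numbers for weaker inhibition; in this assay compound 2 gives 0.5 nM. Compound 1 `CC(C(=O)NCc1ccc(C(F)(F)F)nc1-c1ccc(Cl)cc1)c1ccc(NS(C)(=O)=O)c(F)c1` gives 0.7 nM in this assay. Among the measured compounds shown here, compound 2 thus holds the lowest of the two numbers so far, its nearest being compound 1, and the step of a 1.4-fold lower number from compound 1 to compound 2 (0.15 log units; within the scatter) lies within the scatter, so no order between the two is claimed.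

Compound 3 `CC(C(=O)NCc1ccc(C(F)(F)F)nc1-c1ccsc1)c1ccc(NS(C)(=O)=O)c(F)c1` is still to be measured in this assay. It differs from compound 2 by thiophen-3-yl in place of 4-(tert-butyl)phenyl on an aromatic carbon. For the measured compounds named here, the only measured step that touches this position, a 1.4-fold lower number from compound 1 to compound 2 (0.15 log units; within the scatter), swaps one group on that six-membered aromatic ring of carbon only and stays within the scatter. Going by the values given here, no measured step replaces the whole 4-(tert-butyl)phenyl with a five-membered aromatic ring with 1 hetero atom, so the direction of the present, larger change is not fixed by the data. Because a 1.4-fold lower number from compound 1 to compound 2 (0.15 log units; within the scatter) stayed within the scatter, a change beyond the scatter is not expected with confidence, though a somewhat higher number is estimated to allow for the larger exchange. Compound 3 is expected to give about 2 nM, within 0.5 nM to 8 nM, an estimated step of a 4.0-fold higher number from compound 2 to compound 3 (0.60 log units; beyond the scatter).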

Compound 3, inhibition constant: 2 nM
Compound 3: middle estimate and measured number agree at the digits printed; measured number inside the range.
By their numbers in this assay, from the lowest: compounds 2 and 1 (each within the scatter of the next); then compound 3.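

Replacing the whole aryl group on this aromatic carbon next to the ring nitrogen moves the number in this assay beyond the scatter, and it does so from both earlier compounds (a 4.0-fold higher number from compound 2 to compound 3 (0.60 log units; beyond the scatter); a 2.9-fold higher number from compound 1 to compound 3 (0.46 log units; beyond the scatter)). The position therefore responds to the exchange of a substituted phenyl for thiophen-3-yl, although the swap of chloro for tert-butyl on the phenyl ring stayed within the scatter; both new steps are modest, so the smaller thiophen-3-yl leaves the number only moderately higher. No measurement here bears on the origin of this rise.

The exchange changes several things at once: the ring size, the presence of sulfur and the loss of the substituent carried by the phenyl ring, and the compounds shown do not separate these contributions. As far as these compounds go, how an unsubstituted phenyl, a furan-3-yl, a pyridine ring or a saturated amine such as morpholine on this carbon would read remains open, as does whether thiophen-3-yl behaves the same way with other changes elsewhere on the shared core.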